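The source may hold more compounds than are shown below. What is called first, only, known or untested is meant among the compounds shown, and "the series" means these compounds.

Measured so far in a functional assay on MDA-MB-231 cells (Homo sapiens) for cytotoxicity, read by MTT assay, with a stated time of 48 h; on this read-out lower numbers stand for stronger inhibition and higher numbers for weaker inhibition:
compound 1, `CC(=O)Nc1ccc(NC(=O)NCCCCC(c2ccc(F)cc2)c2ccc(F)cc2)cc1`: > 20000 nM.
compound 2, `CC(=O)Nc1cc(NC(=O)NCCCCC(c2ccc(F)cc2)c2ccc(F)cc2)ccc1Cl`: 9120 nM.

For compound 1 the value > 20000 nM is a limit of the assay, not a number; (the limit of > 20000 nM in this assay, at which 1 of the 2 values shown sits). Compound 2 gives 9120 nM. The step of an at least 2.1-fold lower number from compound 1 to compound 2 (0.34 log units; beyond the scatter) rests on the limit of compound 1, so its size is known only as a lower bound.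

Compound 3, `O=C(NCCCCC(c1ccc(F)cc1)c1ccc(F)cc1)Nc1ccc(Br)cc1I`, is not yet measured. It differs from compound 1 by 4-bromo-2-iodophenyl in place of 4-acetamidophenyl on an amide-type nitrogen. Within the data shown here, the one measured step that bears on this change is an at least 2.1-fold lower number from compound 1 to compound 2 (0.34 log units; beyond the scatter), where 3-acetamido-4-chlorophenyl replaced 4-acetamidophenyl on the same amide-type nitrogen and the number came down out of the limit. In compound 3 the whole 4-acetamidophenyl leaves and 4-bromo-2-iodophenyl enters, so a downward change of roughly the same order is expected, which corresponds to an estimated step of an at least 2.5-fold lower number from compound 1 to compound 3 (0.39 log units; beyond the scatter). Compound 3 is therefore expected near 8000 nM, with a range from 3000 nM to 25000 nM, and it remains possible that only a limit is reported again.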

Compound 3, half-maximal inhibitory concentration: > 20000 nM
Compound 3 gave a limit, no number; the forecaster's own chance of this, stated with the estimate: 30%; at least 2.5-fold (0.39 log units) between middle value and limit.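

In this assay, the replacement of 4-acetamidophenyl on this amide-type nitrogen does not lower the number in every case: the step of an at least 2.1-fold higher number from compound 2 to compound 3 (0.34 log units; beyond the scatter) places 4-bromo-2-iodophenyl behind 3-acetamido-4-chlorophenyl. Among these compounds, compound 2 therefore remains the only compound here with a measured number, and the two halogens of compound 3 do not reproduce its result, so the earlier drop cannot be read as a general effect of leaving 4-acetamidophenyl. The step between the two limit compounds, compound 1 and compound 3, cannot be read, and the series now gathers at a single ceiling: the limit of > 20000 nM in this assay, at which 2 of the 3 values shown sit.

The compounds shown leave open whether the acetamido group, the chlorine or their arrangement in compound 2 accounts for its measured number, and how far compound 1 and compound 3 lie beyond their limits. They also leave open what a plain phenyl group, or a phenyl group carrying an amine or a carboxylic acid, would give on the same nitrogen with the rest of the structure unchanged.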